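From a Cyanopentyl Chain to a Cyclohexyl Ring

The compounds below may be only part of what the source reports. "The series", "measured", "known", "first", "only" and "open" are said of these compounds alone.

In a functional assay on HT-29 cells (Homo sapiens) for inhibition, read by luminescence and CellTiter-Glo, with a stated time of 24 h (on this read-out higher numbers stand for an effect only at larger amounts of compound and lower numbers for an effect already at smaller amounts), compound 1 `CN1C(=S)[C@@H](NC(=O)c2nc(Cc3ccccc3)n(CCC(F)(F)F)n2)COc2ccccc21` gives 1550 nM, and compound 2 `CN1C(=S)[C@@H](NC(=O)c2nc(Cc3ccccc3)n(CCCCCC#N)n2)COc2ccccc21` gives 3830 nM, the higher of the two numbers. Compound 3 `CN1C(=S)[C@@H](NC(=O)c2nc(Cc3ccccc3)n(C3CCCCC3)n2)COc2ccccc21` keeps the shared core but carries cyclohexyl in place of 5-cyanopentyl on an aromatic nitrogen. For the measured compounds named here, only one measured step bears on this change, a 2.5-fold higher number from compound 1 to compound 2 (0.39 log units; beyond the scatter), a modest difference between two open-chain substituents. Going by the values given here, no measured compound shows how a ring behaves at this place, so the comparison is limited. Among the compounds with values here, with only two values available, a step of about that modest size is the most reasonable expectation, and the direction remains uncertain. The expected step is a 1.9-fold lower number from compound 2 to compound 3 (0.28 log units; within the scatter), which leans towards the lower number. In this assay, compound 3 is estimated at 2000 nM, with an expected range of 600 nM to 6000 nM.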

Compound 3, half-maximal effective concentration: 4000 nM
Compound 3: the middle estimate sits 2.0-fold (0.30 log units) below what was measured; low and high end bracket the measured number.
By their numbers in this assay, from the lowest: compound 1; then compounds 2 and 3 (each within the scatter of the next).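

In this assay the only ring shown at this aromatic nitrogen reads the same as the open chain it replaces, with a 1.0-fold higher number from compound 2 to compound 3 (0.02 log units; within the scatter) in the comparison of cyclohexyl with 5-cyanopentyl. The loss of the nitrile and the closing of a six-membered ring of carbon only therefore leave no visible mark on the number here. Against 3,3,3-trifluoropropyl the ring gives a 2.6-fold higher number from compound 1 to compound 3 (0.41 log units; beyond the scatter) and a modest gap, so compound 1 keeps the lowest number of the three, and no evidence at hand accounts for these results.

As far as these compounds go, whether a smaller ring such as cyclopropyl would read any differently at this nitrogen stays open. So does the effect of an amine or a carboxylic acid at the end of a chain here, or of a longer chain ending in trifluoromethyl.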